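Fluoro Added to the Aryl Ring of a Pyrrole Analgesic

The source may hold more compounds than are shown below. What is called first, only, known or untested is meant among the compounds shown, and "the series" means these compounds.

Measured so far:
compound 1, `Cc1c(/C=N\O)cc(-c2ccc(S(C)(=O)=O)cc2)n1-c1ccc(F)c(F)c1`, gives 19%
compound 2, `Cc1c(C#N)cc(-c2ccc(S(C)(=O)=O)cc2)n1-c1cccc(F)c1`, gives 28%

Both compounds were tested in a functional assay on the whole organism (strain Swiss albino) for inhibition, with Mus musculus as the target, in the writhing test, with a stated time of 30 min, at a dose of 10 mg/kg by the oral route; on this read-out higher numbers stand for a stronger effect at the one dose given and lower numbers for a weaker effect. Compound 2 gives 28%, the higher of the two numbers, while compound 1 gives 19%; the gap between them lies within the scatter, so the two cannot be ranked against each other. Among the compounds with values here, no measured pair differs in a single place, so no step size is known from the data.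

Compound 3 `Cc1c(C#N)cc(-c2ccc(S(C)(=O)=O)cc2)n1-c1ccc(F)c(F)c1` is built from compound 2 by fluoro in place of hydrogen on an aromatic carbon. Read one bond further out, the 3-fluorophenyl group becomes the 3,4-difluorophenyl group that compound 1 also carries, but compound 1 bears an oxime rather than a nitrile, so it is not a one-place neighbour of either compound.

With the two measured values so close, the account expects the step from compound 2 to compound 3 to stay inside the scatter, with no clear direction, giving a number 3 percentage points lower from compound 2 to compound 3 (within the scatter). Compound 3 is estimated at 25%, within a range of 10% to 42%.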

Compound 3, a percentage reported as inhibition, in the whole organism at one dose (the size of the read-out at that dose, not a potency): 19%
Compound 3: middle estimate off by 6 percentage points, on the high side; low and high end bracket the measured number.
By their numbers in this assay, from the lowest: compounds 1, 3 and 2 (each within the scatter of the next).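

In this assay, this position now has a step in a single place: the 3-fluorophenyl group becoming the 3,4-difluorophenyl group gives a number 9 percentage points lower from compound 2 to compound 3 (within the scatter), so adding this fluoro, ortho to a fluoro group and para to a large group, produces no difference that can be separated from the usual scatter at this one dose. With the 3,4-difluorophenyl group held constant, the nitrile in place of the oxime gives no change at the digits printed from compound 1 to compound 3 (within the scatter), so that exchange on an aromatic carbon also produces no readable difference in this read-out. Nothing available here bears on why either step came out as it did.

All three compounds lie within the scatter of one another at a single dose and time, so they do not show whether a change at either place can move the read-out clearly. As far as these compounds go, it remains open whether a methoxy group or an amine on this aromatic carbon, or a carboxylic acid in place of the nitrile, would give a number beyond the scatter.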